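A few compounds are considered here, and "the series" means these few. Any claim that something is new, unique, unknown or untested is made for them only; others in the source may bear on it.

The measured compounds in a functional assay on HEL cells (Homo sapiens) for cytotoxicity, read by microscopy; on this read-out lower numbers stand for higher toxicity in this test and higher numbers for lower toxicity in this test:

Compound 1, `Cc1cn([C@@H]2O[C@@H]3COC(=O)[C@]3(OS(C)(=O)=O)[C@H]2O)c(=O)[nH]c1=O`, gives >= 400000 nM; this is a limit of the assay, not a number.
Compound 2, `Cc1cn([C@@H]2O[C@H](CO[Si](C)(C)C(C)(C)C)[C@@]3(OS(=O)(=O)C=C3NC(N)=O)[C@H]2O[Si](C)(C)C(C)(C)C)c(=O)n(C)c1=O`, gives 16000 nM.
Compound 3, `COC(=O)NC1=CS(=O)(=O)O[C@@]12[C@@H](CO[Si](C)(C)C(C)(C)C)O[C@@H](n1cc(C)c(=O)n(C)c1=O)[C@@H]2O[Si](C)(C)C(C)(C)C`, gives >= 50000 nM; this too is a limit of the assay.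

Compound 3 thus stands at a limit rather than a number, and of the three values shown two are such limits, so its place among them can only be said to be on the less toxic side. Going by the values given here, the single measured step that touches it, an at least 3.1-fold higher number from compound 2 to compound 3 (0.49 log units; beyond the scatter), carried the number out of the measurable range.

Compound 4, `Cc1cn([C@@H]2O[C@H](CO[Si](C)(C)C(C)(C)C)[C@@]3(OS(=O)(=O)C=C3NCC(=O)C(N)=O)[C@H]2O[Si](C)(C)C(C)(C)C)c(=O)n(C)c1=O`, carries (carbamoylcarbonyl)methyl in place of methoxycarbonyl on an amine nitrogen. Among the compounds with values here, no measured step covers this exchange itself. What bears on it is that compound 2, with an amino on the carbonyl carbon, gave a number, whereas compound 3 with methoxy did not; compound 4 again bears an amide nitrogen in its new group, so some return toward the number of compound 2 is plausible, but a further limit remains possible because compound 3 already sits at the limit of >= 50000 nM in this assay, at which 1 of the 3 values shown sits. For compound 4 the expected value in this assay is 40000 nM, between 12000 nM and 150000 nM. The step this estimate implies is an at least 1.2-fold lower number from compound 3 to compound 4 (0.09 log units; that floor lies within the scatter), expected to be small or within the scatter.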

Compound 4, minimum cytotoxic concentration: >= 16000 nM
Compound 4 ended at the assay's limit (the forecaster's own chance of this, stated with the estimate: 50%); the middle value is on the limit's open side.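

In this assay compound 4 also ends at a limit of the assay and not at a number: the limit of >= 16000 nM in this assay, at which 1 of the 4 values shown sits. On the amine nitrogen, (carbamoylcarbonyl)methyl in place of carbamoyl gives a number no lower from compound 2 to compound 4 (the limit leaves the size open), and the size of this step and of the step from methoxycarbonyl to the same group cannot be read. Among the compounds shown with this nitrogen substituted, only compound 2, with carbamoyl, gives a number; compound 3 and compound 4 both end at limits, so the amide nitrogen in the new group did not bring back a measured value.

As far as these compounds go, whether compound 3 and compound 4 truly differ in this test remains open, since neither has a number. Also open, from the compounds shown here alone, is what a free amine or a simple longer alkyl chain on this nitrogen would give.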